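Same Aryl Swap Tried on a Thioether Analogue

This account rests on a few compounds, and the source may have more. Where it says the series, first, only, none or still open, it means among the compounds named here.

Measured compounds:
- compound 1, `CC(O)(CS(=O)(=O)c1ccc(Cl)cc1)c1nc(-c2ccc(Cl)cc2)no1` — > 100000 nM
- compound 2, `CC(O)(CS(=O)(=O)c1ccc(Cl)cc1)c1nc(-c2ccc(F)c(Cl)c2)no1` — 35500 nM
- compound 3, `CC(O)(CSc1ccc(Br)cc1)c1nc(-c2ccc(Cl)cc2)no1` — 6500 nM

Of the compounds shown here, three have been tested in a functional assay on DU-145 cells (Homo sapiens) for cytotoxicity, read by MTT assay; a lower number here means a stronger inhibitor, a higher number a weaker inhibitor. Compound 1 gives only a limit there, (the limit of > 100000 nM in this assay, at which 1 of the 3 values shown sits), and not a number. Compound 2 gives 35500 nM, which is an at least 2.8-fold lower number from compound 1 to compound 2 (0.44 log units; beyond the scatter). The change that links these two is 3-chloro-4-fluorophenyl in place of 4-chlorophenyl on an aromatic carbon. Compound 3 is built on a different core, and the difference between the core of compound 3 and the core of compound 1 is not broken down here. In this assay compound 3 gives 6500 nM, the lowest number among the measured compounds, with compound 2 the nearest.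

Compound 4, `CC(O)(CSc1ccc(Br)cc1)c1nc(-c2ccc(F)c(Cl)c2)no1`, has not yet been measured. It is made from compound 3 by 3-chloro-4-fluorophenyl in place of 4-chlorophenyl on an aromatic carbon, the same change that turned compound 1 into compound 2. The expectation for compound 4 rests on that earlier step, which was an at least 2.8-fold lower number from compound 1 to compound 2 (0.44 log units; beyond the scatter), applied now to the stronger starting point of compound 3 at 6500 nM. For compound 4 the expected step is a 2.8-fold lower number from compound 3 to compound 4 (0.45 log units; beyond the scatter). Compound 4 is therefore estimated at 2300 nM, with a likely range from 800 nM to 6500 nM.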

Compound 4, half-maximal inhibitory concentration: 8800 nM
Compound 4: middle estimate off by 3.8-fold (0.58 log units), on the low side; the whole stated range lies below it.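

In this assay, the step on the core of compound 3 is a 1.4-fold higher number from compound 3 to compound 4 (0.13 log units; within the scatter), so on this core, putting 3-chloro-4-fluorophenyl in place of 4-chlorophenyl has no effect that can be told apart from ordinary variation between repeat measurements. A swap that seemed helpful on one core therefore did not carry over to the other with the same size, a reminder that a step seen once cannot simply be added to a new starting compound: the same change on two cores in this assay, an at least 2.8-fold lower number (0.44 log units; beyond the scatter) from compound 1 to compound 2 and a 1.4-fold higher number (0.13 log units; within the scatter) from compound 3 to compound 4, at least 3.8-fold (0.58 log units) apart, beyond the scatter of two such steps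

This does not show why the two cores respond differently, nor does it give a general rule for the series, since it rests on only two pairs, and the first step is only a bound, as compound 1 gives a limit of the assay and not a number: the limit of > 100000 nM in this assay, at which 1 of the 4 values shown sits.

The compounds shown leave open which part of the difference between the two cores matters, since no pair here differs in that part alone. As far as these compounds go, it also remains open how the swap would behave on a core with a methoxy group, a nitrile or an amine on the aromatic ring attached through sulfur.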